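A few compounds are considered here, and "the series" means these few. Any claim that something is new, unique, unknown or untested is made for them only; others in the source may bear on it.

Compound 1 `COc1ccc(N(CC(=O)NCCC[Se]c2ccccc2)C(=O)/C=C/c2ccccc2)cc1` in an ADME assay on cells (Fibroblast, Homo sapiens) for cytotoxicity, read by MTT assay, with a stated time of 24 h (on this read-out lower numbers stand for stronger inhibition and higher numbers for weaker inhibition), gives >= 100000 nM, a limit of the assay rather than a number.
Compound 2 `COc1ccc(N(CC(=O)NCCCSc2ccccc2)C(=O)CNC(=O)OC(C)(C)C)cc1` in this assay gives >= 100000 nM, again a limit.
Compound 3 `COc1ccc(N(CC(=O)NCCC[Se]c2ccccc2)C(=O)C#Cc2ccccc2)cc1` in this assay gives >= 100000 nM, also a limit.

Compound 3 therefore stands where every measured compound stands: at the limit of this assay, with no number of its own to rank it against the other two. Within the data shown here, the only step that can be drawn among the measured compounds, a step that the two limits leave unreadable from compound 1 to compound 3, runs between two limits and cannot be read for size or direction, because the limit of >= 100000 nM in this assay, at which 3 of the 3 values shown sit, is the point at which all three values sit.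

Compound 4 `COc1ccc(N(CC(=O)NCCCSc2ccccc2)C(=O)C#Cc2ccccc2)cc1` is the next compound, and it differs from compound 3 in one place: a group of 7 heavy atoms (6 carbon, 1 sulfur; one six-membered aromatic ring of carbon only) in place of a group of 7 heavy atoms (6 carbon, 1 selenium; one six-membered aromatic ring of carbon only), on a saturated chain carbon, three bonds along the chain from an amide-type nitrogen. Among the measured compounds shown here, no measured step tests this exchange of a selenium-containing group for a sulfur-containing one, but compound 2, which already carries phenylsulfanyl, gives a limit in this assay just as the selenium compounds do. The expectation is therefore that compound 4 gives no number either. The step this estimate implies, a number no higher from compound 3 to compound 4 (the limit leaves the size open), is expected to be none beyond the scatter. Compound 4 is estimated at 100000 nM in this assay, with a range from 50000 nM to 300000 nM, most likely reported again as a limit.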

Compound 4, half-maximal inhibitory concentration: >= 100000 nM
Compound 4 ended at the assay's limit (the forecaster's own chance of this, stated with the estimate: 85%); the middle value sits exactly at the limit.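

The steps from compound 3 and compound 2 to compound 4 cannot be read for size or direction, because each runs between two limits: the limit of >= 100000 nM in this assay, at which 4 of the 4 values shown sit. The compounds shown leave open how these four would rank in this assay, and whether phenylsulfanyl and the selenium-containing group differ there at all.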